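Swapping the Anilino Group on a Trimethoxyphenyl Core

A few compounds are considered here, and "the series" means these few. Any claim that something is new, unique, unknown or untested is made for them only; others in the source may bear on it.

Compound 2 `CC(C)c1ccc(-c2nc(SCc3cn(CC(=O)NC(=O)Nc4ccccn4)nn3)nc(Nc3cccc(C(F)(F)F)c3)c2C#N)cc1` serves as the reference point. In a functional assay on ECa-109 cells (Homo sapiens) for inhibition, read by MTT assay, with a stated time of 72 h (on this read-out higher numbers stand for weaker inhibition and lower numbers for stronger inhibition), compound 2 gives 24200 nM. Compound 1 `CC(C)c1ccc(-c2nc(SCc3cn(CC(=O)NC(=O)Nc4ccccn4)nn3)nc(Nc3ccc(Cl)cc3)c2C#N)cc1` carries 4-chlorophenyl in place of 3-(trifluoromethyl)phenyl on a nitrogen on an aromatic ring, and in this assay compound 1 gives 11200 nM, which is a 2.2-fold lower number from compound 2 to compound 1 (0.33 log units; beyond the scatter). Compound 3 `COc1cc(-c2nc(SCc3cn(CC(=O)NC(=O)Nc4ccccn4)nn3)nc(Nc3cccc(C(F)(F)F)c3)c2C#N)cc(OC)c1OC` differs from compound 2 by 3,4,5-trimethoxyphenyl in place of 4-isopropylphenyl on an aromatic carbon. For compound 3 in this assay the result is only a limit, > 64000 nM, namely (the limit of > 64000 nM in this assay, at which 1 of the 3 values shown sits). Set against compound 2, this is an at least 2.6-fold higher number from compound 2 to compound 3 (0.42 log units; beyond the scatter). Compound 4 `COc1cc(-c2nc(SCc3cn(CC(=O)NC(=O)Nc4ccccn4)nn3)nc(Nc3ccc(Cl)cc3)c2C#N)cc(OC)c1OC` has not yet been measured; it stands to compound 3 as compound 1 stands to compound 2, through the same change (4-chlorophenyl in place of 3-(trifluoromethyl)phenyl on a nitrogen on an aromatic ring). Compound 4 is therefore expected to show an at least 1.4-fold lower number from compound 3 to compound 4 (0.15 log units; that floor lies within the scatter). That expectation rests on compound 1 and its step of a 2.2-fold lower number from compound 2 to compound 1 (0.33 log units; beyond the scatter). Since compound 3 carries only a limit, the estimate for compound 4 is 45000 nM, expected to fall between 20000 nM and 100000 nM.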

Compound 4, half-maximal inhibitory concentration: > 64000 nM
Compound 4 ended at the assay's limit; the forecaster's own chance of this, stated with the estimate: 45%; at least 1.4-fold (0.15 log units) between middle value and limit.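

In this assay, 3,4,5-trimethoxyphenyl in place of 4-isopropylphenyl also raises the number on the core bearing the 4-chlorophenyl group, with an at least 5.7-fold higher number from compound 1 to compound 4 (0.75 log units; beyond the scatter). This change points the same way on both cores, but its size on the two cannot be compared: the same change on two cores in this assay, an at least 2.6-fold higher number (0.42 log units; beyond the scatter) from compound 2 to compound 3 and an at least 5.7-fold higher number (0.75 log units; beyond the scatter) from compound 1 to compound 4; the limit leaves it open whether they differ. Going by these compounds, compound 3 and compound 4 both stand at the assay's limit, so the step between them cannot be read, and it remains unknown whether a 2.2-fold lower number from compound 2 to compound 1 (0.33 log units; beyond the scatter) carries over to the trimethoxyphenyl core: the limit of > 64000 nM in this assay, at which 2 of the 4 values shown sit.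

The compounds shown leave open how the two anilino groups would rank on a core whose values fall within the assay's range. They also leave open what a phenyl group carrying an amine or a carboxylic acid would give in place of 4-isopropylphenyl.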